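Swapping a Benzylic Naphthyl for Chlorophenyl: Expected Half-Life

The source may report more compounds than this note shows. Statements on the series, on what has been measured and on what is new or still open speak of the compounds shown alone.

Measured compounds:
compound 1 `Cc1cc(-c2ccccc2)n(/C(N)=N/S(=O)(=O)c2cc(C)c(Cl)cc2SCc2cccc3ccccc23)n1`, 0.256 h
compound 2 `Cc1cc(S(=O)(=O)/N=C(\N)n2nccc2-c2ccccc2)c(SCc2cccc3ccccc23)cc1Cl`, 0.268 h
compound 3 `Cc1cc(-c2ccccc2)n(/C(N)=N/S(=O)(=O)c2cc(C)c(Cl)cc2SCc2ccc(Cl)cc2)n1`, 0.24 h

In an ADME assay on microsomes from liver (Homo sapiens) for metabolic stability, read by LC-MS, using NADPH, tested at 5 uM (on this read-out higher numbers stand for a longer-lived compound and lower numbers for a shorter-lived compound), compound 2 gives 0.268 h, and this sits within the scatter of compound 1 and compound 3, so the three numbers cannot be told apart. The step of a 1.0-fold higher number from compound 1 to compound 2 (0.02 log units; within the scatter) and the step of a 1.1-fold lower number from compound 1 to compound 3 (0.03 log units; within the scatter) both stay within the scatter.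

Compound 4 `Cc1cc(S(=O)(=O)/N=C(\N)n2nccc2-c2ccccc2)c(SCc2ccccc2Cl)cc1Cl` has not been measured. It differs from compound 2 by 2-chlorophenyl in place of naphthalen-1-yl on a saturated chain carbon bound to a sulfur. For the measured compounds named here, the step that bears on this is the one from compound 1 to compound 3, where a 4-chlorophenyl replaced the naphthalen-1-yl on the same saturated chain carbon bound to a sulfur, and it gave a 1.1-fold lower number from compound 1 to compound 3 (0.03 log units; within the scatter). Going by the values given here, the data hold no step in which a 2-chlorophenyl enters at that place, so the expectation rests on the 4-chlorophenyl analogue alone. Compound 4 is therefore expected to show no step beyond the scatter, a 1.0-fold lower number from compound 2 to compound 4 (0.01 log units; within the scatter), and its estimated value in this assay is 0.26 h, in the range 0.13 h to 0.52 h.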

Compound 4, half-life: 0.226 h
The estimate for compound 4 lay 1.2-fold (0.06 log units) above the measured number; the range from low to high includes it.
By their numbers in this assay, from the lowest: compounds 4, 3, 1 and 2 (each within the scatter of the next).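

Compound 4 shows that a second chlorophenyl can replace naphthalen-1-yl on a saturated chain carbon bound to a sulfur without a readable shift in half-life in this assay, giving a 1.2-fold lower number from compound 2 to compound 4 (0.07 log units; within the scatter). The earlier compounds shown here showed this only for 4-chlorophenyl, in a 1.1-fold lower number from compound 1 to compound 3 (0.03 log units; within the scatter); the same result now holds for 2-chlorophenyl, on the core of compound 2, and with one aromatic ring entering where two leave. Nothing measured here explains why the half-life stays within the scatter across these changes.

The compounds shown leave open whether an amine, a carboxylic acid or a longer chain at this place would move the half-life beyond the scatter. They also leave open how 2-chlorophenyl and 4-chlorophenyl compare on one and the same core.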